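The source may report more compounds than this note shows. Statements on the series, on what has been measured and on what is new or still open speak of the compounds shown alone.

Measured in a functional assay on BaF3 cells (Mus musculus) for inhibition, read by CCK-8 assay, with a stated time of 72 h; on this read-out lower numbers stand for stronger inhibition of growth and higher numbers for weaker inhibition of growth:
- compound 1 `COc1ccc(CNc2cc(Oc3ccc(NC(=O)Nc4ccc(C)c(C(F)(F)F)c4)cc3)ncn2)cc1`: 1000 nM
- compound 2 `CCN1CCN(Cc2ccc(NC(=O)Nc3ccc(Oc4cc(NC(C)=O)ncn4)cc3)cc2C(F)(F)F)CC1`: 38 nM
- compound 3 `Cc1ccc(NC(=O)Nc2ccc(Oc3cc(N(C)CCN(C)C)ncn3)cc2)cc1C(F)(F)F`: 9410 nM

Compound 3 has the highest number of the three, beyond the scatter from both others. Compound 4 `Cc1ccc(NC(=O)Nc2ccc(Oc3cc(NCCN)ncn3)cc2)cc1C(F)(F)F` has (2-aminoethyl)amino in place of (2-(dimethylamino)ethyl)(methyl)amino on an aromatic carbon. For the measured compounds named here, only one measured step changes this place: a 9.4-fold higher number from compound 1 to compound 3 (0.97 log units; beyond the scatter), a modest step in which (2-(dimethylamino)ethyl)(methyl)amino replaced (4-methoxybenzyl)amino. Going by the values given here, no measured compound carries (2-aminoethyl)amino, so the direction is uncertain. A modest step towards a lower number in this assay is expected, no larger than that one. The expected step is a 2.7-fold lower number from compound 3 to compound 4 (0.43 log units; beyond the scatter). For compound 4 the estimated value is 3500 nM, with an expected range of 800 nM to 12000 nM.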

Compound 4, concentration for 50% growth inhibition: > 10000 nM
Compound 4 gave a limit, no number; the forecaster's own chance of this, stated with the estimate: 20%; at least 2.8-fold (0.45 log units) between middle value and limit.
By their numbers in this assay, from the lowest: compound 2; then compound 1; then compound 3. At a limit, above all of these: compound 4.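

In this assay compound 4 gave > 10000 nM, which is a limit and not a number. The change to (2-aminoethyl)amino gives an at least 1.0-fold higher number from compound 3 to compound 4 (0.02 log units; that floor lies within the scatter), so this change brought no lower number and the two compounds cannot be ordered. In place of (4-methoxybenzyl)amino, the same group gives an at least 10-fold higher number from compound 1 to compound 4 (1.00 log units; beyond the scatter), so both amine chains shown at this place end up with higher numbers than the benzyl group.

On these data alone, how far compound 4 lies beyond its limit stays open. So does whether a longer amine chain or a carboxylic acid at this place would lower the number.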